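The source may report more compounds than this note shows. Statements on the series, on what has been measured and on what is new or still open speak of the compounds shown alone.

Measured in an ADME assay on BHK cells (Mesocricetus auratus) for cytotoxicity, read by MTT assay; on this read-out lower numbers stand for higher toxicity in this test and higher numbers for lower toxicity in this test:

compound 1, `CC1CCCCC1N(CCCCCCN1C[C@H](O)[C@@H](O)[C@H](O)[C@H]1CO)C(=O)OC(C)(C)C`, gives 230000 nM.
compound 2, `CC(C)(C)CC(=O)N(CCCCCCN1C[C@H](O)[C@@H](O)[C@H](O)[C@H]1CO)C1CCCCC1`, gives only a limit of the assay, > 500000 nM.
compound 3, `CC(C)(C)C(=O)N(CCCCCCN1C[C@H](O)[C@@H](O)[C@H](O)[C@H]1CO)c1cc(F)ccc1F`, likewise gives only a limit of the assay, > 500000 nM.

Compound 3 therefore has no number of its own in this assay; it sits at the limit of > 500000 nM in this assay, at which 2 of the 3 values shown sit, and only compound 1 returns an actual number. Among the measured compounds shown here, the three compounds share a core and differ in the groups on the amide-type nitrogen and on its carbonyl side, so no pair among them differs in just one place, and no measured step can be read from them.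

Compound 4, `CC(C)(C)C(=O)N(CCCCCCN1C[C@H](O)[C@@H](O)[C@H](O)[C@H]1CO)C1CCCCCCC1`, is not yet measured. It differs from compound 3 in one place: cyclooctyl in place of 2,5-difluorophenyl on an amide-type nitrogen. For the measured compounds named here, with compound 3 at a limit and no measured step to lean on, the expectation for compound 4 is simply that it stays near that limit, so the estimated step of a number no higher from compound 3 to compound 4 (the limit leaves the size open) is none beyond the scatter. The estimate for compound 4 in this assay is 500000 nM, with a range from 200000 nM to 1500000 nM, and a fair chance that only a limit is reported again.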

Compound 4, half-maximal cytotoxic concentration: 208000 nM
The estimate for compound 4 lay 2.4-fold (0.38 log units) above the measured number, within the range that was stated.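

In this assay, putting cyclooctyl in place of 2,5-difluorophenyl on the amide-type nitrogen gives an at least 2.4-fold lower number from compound 3 to compound 4 (0.38 log units; beyond the scatter) and so higher toxicity in this test. This is the only change in a single place among the compounds shown, and it is the first sign that the group on this nitrogen can move the read-out beyond the usual scatter. Going by these compounds, the true size of the step stays open, since its starting point is a limit and not a number: the limit of > 500000 nM in this assay, at which 2 of the 4 values shown sit.

This one change swaps ring size, aromatic character and fluorine together, and the compounds shown do not separate these. Also open, on these data alone, is how a plain phenyl or a ring carrying an amine would behave on this nitrogen with the same carbonyl side.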